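Isopropyl in Place of Trifluoroethyl on the Shared Core

A few compounds are considered here, and "the series" means these few. Any claim that something is new, unique, unknown or untested is made for them only; others in the source may bear on it.

In an assay for inhibition of Rho-associated protein kinase 1 (Homo sapiens), read by TR-FRET, with stated times of 5 min and 2 h (a higher number here means a weaker inhibitor, a lower number a stronger inhibitor), compound 2 `CC1(CC(F)(F)F)NC(=O)c2sc(-c3ccncc3)cc2N1` gives 31 nM. For the measured compounds named here, that is the lowest of the two numbers measured so far, yet its nearest neighbour, compound 1 `CCCC1(C)NC(=O)c2sc(-c3ccncc3)cc2N1`, gives 33 nM in this assay, and the two values lie within the scatter of each other. Going by the values given here, the only measured step, a 1.1-fold lower number from compound 1 to compound 2 (0.03 log units; within the scatter), shows that exchanging one group for another on the saturated chain carbon bound to a saturated ring carbon left the number essentially unchanged.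

Compound 3 `CC(C)C1(C)NC(=O)c2sc(-c3ccncc3)cc2N1` has not yet been measured in this assay. It differs from compound 2 in one place: isopropyl in place of 2,2,2-trifluoroethyl on a saturated ring carbon. The step from compound 1 to compound 2 is the only one that bears on this change, and it was within the scatter, so a change of similar size is the most reasonable expectation. Compound 3 is therefore expected to give about 35 nM in this assay, with a range from 15 nM to 80 nM. This estimate means a step of a 1.1-fold higher number from compound 2 to compound 3 (0.05 log units; within the scatter), expected to stay within the scatter.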

Compound 3, half-maximal inhibitory concentration: 35 nM
For compound 3 middle estimate and measured number coincide at the digits printed; the measured number falls inside the stated range.
By their numbers in this assay, from the lowest: compounds 2, 1 and 3 (each within the scatter of the next).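

In this assay, the earlier pair had varied only the end of a chain, whereas the position on the saturated ring carbon now carries three different groups, and the exchange of 2,2,2-trifluoroethyl for isopropyl is a 1.1-fold higher number from compound 2 to compound 3 (0.05 log units; within the scatter). The exchange of propyl for isopropyl is a 1.1-fold higher number from compound 1 to compound 3 (0.03 log units; within the scatter), so neither new step separates isopropyl from the other two groups, even though isopropyl has fewer heavy atoms than 2,2,2-trifluoroethyl and no fluorine. Nothing available here accounts for how closely these three groups read.

As far as these compounds go, all three groups are small, without a ring, and carry no charge, so what an amine, a carboxylic acid, a cyclopropyl ring or a longer chain would do on this carbon remains open. From the compounds shown here alone, whether any group at this position can move the number beyond the scatter also remains open.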